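Benzoxazole sulfonamides: cytotoxicity in human embryonic kidney cells

The compounds below may be only part of what the source reports. "The series", "measured", "known", "first", "only" and "open" are said of these compounds alone.

Measured so far:
Compound 1, `O=S(=O)(Nc1ccc2oc(-c3ccccc3)nc2c1)c1ccccc1O`: 33000 nM
Compound 2, `COc1ccc(Cl)cc1S(=O)(=O)Nc1ccc(-c2nc3ccccc3o2)cc1`: 75000 nM

Both compounds were tested in an ADME assay on HEK293 cells (Homo sapiens) for cytotoxicity, read by resazurin assay, with a stated time of 48 h; on this read-out higher numbers stand for lower toxicity in this test and lower numbers for higher toxicity in this test. Compound 1 gives 33000 nM, the lowest of the two numbers; compound 2 gives 75000 nM, a number beyond the usual scatter above that of compound 1. Within the data shown here, no step between measured compounds that differ in one place is available, so the two values stand on their own.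

Compound 3, `COc1ccc(S(=O)(=O)Nc2ccc3oc(-c4ccccc4)nc3c2)cc1`, has not yet been measured in this assay. It differs from compound 1 in one place: 4-methoxyphenyl in place of 2-hydroxyphenyl on a sulfonyl sulfur. Nothing in the measured pair isolates this change, so the step from compound 1 to compound 3 is expected to be small, at most modestly upward, and may well lie within the scatter: a 1.4-fold higher number from compound 1 to compound 3 (0.13 log units; within the scatter). Compound 3 is therefore estimated at 45000 nM in this assay, with a range from 20000 nM to 100000 nM.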

Compound 3, half-maximal cytotoxic concentration: 91000 nM
Compound 3: the middle estimate sits 2.0-fold (0.31 log units) below what was measured; the range from low to high includes it.
By their numbers in this assay, from the lowest: compound 1; then compounds 2 and 3 (each within the scatter of the next).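

In this assay, the group on the sulfonyl sulfur proves able to shift the read-out on its own: with the rest of the structure unchanged, 4-methoxyphenyl in place of 2-hydroxyphenyl gives a 2.8-fold higher number from compound 1 to compound 3 (0.44 log units; beyond the scatter), toward lower toxicity in this test. The swap removes the hydrogen-bond donor counted in the leaving group and adds one heavy atom, and this single step cannot tell which part of the swap matters. Nothing available explains the rise in the number.

The compounds shown leave open whether the hydroxy or the methoxy group, or the place each occupies on the phenyl ring, accounts for the step. They also leave open how a 4-hydroxyphenyl, a 2-methoxyphenyl or an aminophenyl group on the sulfonyl sulfur would read.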